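A few compounds are considered here, and "the series" means these few. Any claim that something is new, unique, unknown or untested is made for them only; others in the source may bear on it.

In a functional assay on HT-29 cells (Homo sapiens) for antiproliferative activity, read by sulforhodamine B assay, with a stated time of 48 h (on this read-out lower numbers stand for stronger inhibition and higher numbers for weaker inhibition), compound 1 (`CCCN1CCN(c2ccc(S(=O)(=O)Oc3ccccc3C)cc2)C1=O`) reads > 100000 nM and this is a limit of the assay, not a number. Among the compounds with values here, compound 2 (`CCCN1CCN(c2ccc(S(=O)(=O)Oc3cccc(F)c3)cc2)C1=O`) gives 18000 nM as the only actual number so far. Compound 3 (`CCCN1CCN(c2ccc(S(=O)(=O)Oc3ccc(C)cc3)cc2)C1=O`) carries 4-methylphenyl in place of 3-fluorophenyl on an oxygen and has not yet been measured. Within the data shown here, the one measured step that bears on this also swaps the group on that oxygen: it is an at least 5.5-fold lower number from compound 1 to compound 2 (0.74 log units; beyond the scatter) and it shows that such a swap can shift the number beyond the scatter. A single step gives no firm direction for 4-methylphenyl, so no shift beyond the scatter is expected in this assay, although the uncertainty is wide. The expected change is a 1.1-fold higher number from compound 2 to compound 3 (0.05 log units; within the scatter) and it stays small. For compound 3 the estimate is 20000 nM with an expected range from 5000 nM to 70000 nM as the likely span.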

Compound 3, half-maximal inhibitory concentration: 25000 nM
The estimate for compound 3 lay 1.3-fold (0.10 log units) below the measured number, within the range that was stated.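

The step from 3-fluorophenyl to 4-methylphenyl on the oxygen is a 1.4-fold higher number from compound 2 to compound 3 (0.14 log units; within the scatter), so in this assay these two groups cannot be told apart. Within the data shown here, the step from 2-methylphenyl to 4-methylphenyl is an at least 4.0-fold lower number from compound 1 to compound 3 (0.60 log units; beyond the scatter), which shows for the first time that two phenyl groups, each carrying a methyl, can read differently when only the place of that methyl changes. For compound 1, > 100000 nM is a limit of the assay and not a number, and this step rests on that limit: the limit of > 100000 nM in this assay, at which 1 of the 3 values shown sits.

The compounds shown leave open how an unsubstituted phenyl, 3-methylphenyl or 4-fluorophenyl on this oxygen would compare, so the separate roles of methyl, fluorine and their places remain unsettled. They also leave open whether a phenyl group carrying an amine or a carboxylic acid would move the number.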